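Trading 4-chlorobenzyl for 4-fluorobenzyl

The compounds below may be only part of what the source reports. "The series", "measured", "known", "first", "only" and "open" are said of these compounds alone.

Three compounds measured so far in an ADME assay on the whole organism (strain Sprague-Dawley) for pharmacokinetics, with Rattus norvegicus as the target, using cassette dosing, at a dose of 1 mg/kg by the oral route (on this read-out higher numbers stand for higher oral bioavailability and lower numbers for lower oral bioavailability), are:
Compound 1 `O=c1ccc(-c2cc(C[C@]3(O)CC[C@@H](Cc4ccc(Cl)cc4)CC3)no2)c[nH]1` gives 37.2%
Compound 2 `O[C@]1(Cc2cc(-c3cn[nH]c3)on2)CC[C@H](Cc2ccccc2)CC1` gives 46.3%
Compound 3 `O[C@]1(Cc2cc(-c3cn[nH]c3)on2)CC[C@H](Cc2ccc(Cl)cc2)CC1` gives 72.8%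

Compound 3 stands highest of the three at 72.8% on this read-out. Compound 4 `O[C@]1(Cc2cc(-c3cn[nH]c3)on2)CC[C@H](Cc2ccc(F)cc2)CC1` differs from it by fluoro in place of chloro on an aromatic carbon and has fluoro in place of chloro on an aromatic carbon. The nearest evidence is a number 26.5 percentage points higher from compound 2 to compound 3 (beyond the scatter) and is a modest step for chloro in place of hydrogen on an aromatic carbon. The large step of a number 35.6 percentage points higher from compound 1 to compound 3 (beyond the scatter) concerns a different group and says little here. Going by the values given here, no fluoro compound has been measured, so only part of the chloro gain is expected to remain in this assay and the number is expected to fall. The expected step is a number 12.8 percentage points lower from compound 3 to compound 4 (beyond the scatter) by this estimate. For compound 4 the estimate is 60% with 42% to 78% as the expected range.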

Compound 4, oral bioavailability: 78%
Estimate against measurement, compound 4: 18 percentage points below; measured number inside the range.
By their numbers in this assay, from the lowest: compounds 1 and 2 (each within the scatter of the next); then compounds 3 and 4 (each within the scatter of the next).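

In this assay, the step of a number 5.2 percentage points higher from compound 3 to compound 4 (within the scatter) shows that fluoro in place of chloro at this position leaves the read-out within the scatter. The step of a number 31.7 percentage points higher from compound 2 to compound 4 (beyond the scatter) shows that the gain over hydrogen at this place is not particular to chloro, as compounds 2 and 3 alone could not show. No available measurement accounts for this.

As far as these compounds go, whether methoxy, nitrile or trifluoromethyl at the same place would hold the number stays open. So does whether fluoro would behave alike on the core of compound 1.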